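The compounds below may be only part of what the source reports. "The series", "measured", "known", "first", "only" and "open" are said of these compounds alone.

Measured compounds:
- compound 1, `C=CCNC(=O)/C(C)=C(\C)c1ccc(Br)cc1`, 33.7 mg/kg in a functional assay on the whole organism (strain Icem-CET (SPF Caw)) for inhibition, with Mus musculus as the target, with a stated time of 30 min; a higher number here means that more compound is needed for the effect, a lower number that less compound is needed
- compound 2, `C/C(C(=O)NC1CC1)=C(/C)c1ccc(Cl)cc1`, 11.4 mg/kg

Both compounds were examined in this assay, where the read-out is the dose giving a half-maximal effect. Compound 2 stands at the lowest of the two numbers; its nearest neighbour, compound 1, returns a higher number, a gap that lies beyond the scatter of repeated runs. The two measured compounds differ in more than one place, so the numbers alone do not say which change carries the difference.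

Compound 3, `C=CCNC(=O)/C(C)=C(\C)c1ccc(Cl)cc1`, has not yet been measured. Against compound 2 it shows one change: allyl in place of cyclopropyl on an amide-type nitrogen. Compound 1 also carries an allyl on its amide-type nitrogen and gives the higher number, which speaks for a modest rise in this assay. The author expects the step of a 1.8-fold higher number from compound 2 to compound 3 (0.24 log units; within the scatter) to be small, at or just beyond the scatter. For compound 3 the estimated value in this assay is 20 mg/kg, within a range from 8 mg/kg to 50 mg/kg.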

Compound 3, dose for half-maximal effect: 18.6 mg/kg
Beside the measured number, compound 3's estimate is 1.1-fold (0.03 log units) above it; measured number inside the range.
By their numbers in this assay, from the lowest: compounds 2, 3 and 1 (each within the scatter of the next, the first and the last beyond it).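

In this assay compound 3 joins the two earlier compounds through single changes, so that each change can be read alone: allyl in place of cyclopropyl on an amide-type nitrogen gives a 1.6-fold higher number from compound 2 to compound 3 (0.21 log units; within the scatter) and chloro in place of bromo on an aromatic carbon gives a 1.8-fold lower number from compound 1 to compound 3 (0.26 log units; within the scatter) and neither step lies beyond the scatter of repeated runs. At the amide-type nitrogen, the three-membered ring of cyclopropyl can therefore give way to the ring-free allyl with its double bond without a difference these measurements can resolve, and the same holds for the exchange of bromo for chloro on the aromatic carbon. No measured evidence is available that bears on these two steps. The compounds shown leave open how a longer chain or a chain ending in an amine on the amide-type nitrogen would read in this assay and how fluoro or methoxy would read in place of chloro on the aromatic carbon. They also leave open what a methyl in place of the amide hydrogen would do to the number.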